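A few compounds are considered here, and "the series" means these few. Any claim that something is new, unique, unknown or untested is made for them only; others in the source may bear on it.

- Compound 1 `CNC(=O)c1cc(C(N)=O)cc2c1OC[C@H]2c1ccccc1`: 2.7
- Compound 2 `CNC(=O)c1cc(C(=O)Nc2cnn(C)c2)cc2c1OC[C@H]2c1ccccc1`: 3.5

In a physicochemical assay for lipophilicity, at pH 7.4 (a lower number here means a more polar compound, a higher number a more lipophilic compound), compound 2 stands highest of the two measured compounds at 3.5, and compound 1 lies lower at 2.7. Compound 3 `CNC(=O)c1cc(C(=O)NC)c2c(c1)[C@H](c1ccccc1)CO2` has not yet been measured. It differs from compound 2 as follows: methyl in place of 1-methyl-1H-pyrazol-4-yl on an amide-type nitrogen. In words, this is methyl in place of 1-methyl-1H-pyrazol-4-yl on an amide-type nitrogen.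

Among the measured compounds shown here, only one measured step bears on this change. It is a number 0.80 log units higher from compound 1 to compound 2 (beyond the scatter), a modest step beyond the scatter, with 1-methyl-1H-pyrazol-4-yl in place of hydrogen on an amide-type nitrogen. For the measured compounds named here, the same group leaves on the way to compound 3, but methyl rather than hydrogen takes its place, and no measured step shows that swap directly. A fall somewhat smaller than the rise in a number 0.80 log units higher from compound 1 to compound 2 (beyond the scatter) is therefore expected in this assay. The expected change is a number 0.60 log units lower from compound 2 to compound 3 (beyond the scatter). The estimate for compound 3 is 2.9, with an expected range of 2.6 to 3.3.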

Compound 3, distribution coefficient: 3.2
Compound 3: middle estimate off by 0.30 log units, on the low side; the measured number falls inside the stated range.
By their numbers in this assay, from the lowest: compound 1; then compounds 3 and 2 (each within the scatter of the next).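

In this assay the exchange of 1-methyl-1H-pyrazol-4-yl for methyl on the amide-type nitrogen gives a number 0.30 log units lower from compound 2 to compound 3 (within the scatter) and so does not separate the group of 6 heavy atoms from the single carbon of methyl at this position. Methyl in place of hydrogen on the same nitrogen gives a number 0.50 log units higher from compound 1 to compound 3 (beyond the scatter) and thus shows that the pyrazole ring is not needed for a step up from compound 1 in this measurement. No measurement shown offers a reason for these numbers.

Going by these compounds, whether a longer chain such as propyl, a phenyl ring, or a chain ending in an amine or a carboxylic acid would read like methyl on this nitrogen remains open. On these data alone, it is also open whether the same steps would hold on a core other than the shared one.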